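The compounds below may be only part of what the source reports. "The series", "measured", "known", "first", "only" and "open" are said of these compounds alone.

Measured compounds:
compound 1 `CCCCCCCCNC(=O)[C@@H](NC(=O)c1cc2ccccc2o1)[C@@H](C)O` gives 200000 nM in a functional assay on SW-620 cells (Homo sapiens) for cytotoxicity, read by MTT assay, with a stated time of 48 h; a lower number here means a stronger inhibitor, a higher number a weaker inhibitor;
compound 2 `CCCCCCCCCCCCNC(=O)[C@@H](NC(=O)c1cc2ccccc2o1)[C@@H](C)O` gives 21300 nM in this assay;
compound 3 `CCCCCCCCCCCCCCCCCCNC(=O)[C@@H](NC(=O)c1cc2ccccc2o1)[C@@H](C)O` gives only a limit of the assay in this assay, > 200000 nM.

Going by the values given here, compound 3 thus stands at the limit of this assay, where, as the limit of > 200000 nM in this assay, at which 1 of the 3 values shown sits, shows, it is the one value of the three that is a limit and not a number. Compound 4 `CCCCCCCCCCCCCCCCCCNC(=O)[C@@H](NS(=O)(=O)c1ccc(C)cc1)[C@@H](C)O` keeps the octadecyl chain of compound 3 and differs from it in one place: (4-methylphenyl)sulfonyl in place of (1-benzofuran-2-yl)carbonyl on an amine nitrogen.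

Among the compounds with values here, no measured step touches this change; the three measured steps all concern the chain length on the other amide. Those steps were a 9.4-fold lower number from compound 1 to compound 2 (0.97 log units; beyond the scatter) and an at least 9.3-fold higher number from compound 2 to compound 3 (0.97 log units; beyond the scatter), and between compound 1 and compound 3 a number no lower from compound 1 to compound 3 (the limit leaves the size open). They show that the octadecyl chain, common to compound 3 and compound 4, sits on the weak side of the numbers. Nothing in the data says whether the sulfonyl for carbonyl exchange moves the number, so the expectation for compound 4 is that it stays with compound 3 at the limit, that is a number no higher from compound 3 to compound 4 (the limit leaves the size open) is expected to be no change beyond the scatter. Compound 4 is therefore estimated at 200000 nM, within 60000 nM to 600000 nM, most likely reported again as a limit.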

Compound 4, half-maximal inhibitory concentration: 32500 nM
Compound 4: the middle estimate sits 6.2-fold (0.79 log units) above what was measured; measured number outside the range, below it.
By their numbers in this assay, from the lowest: compounds 2 and 4 (each within the scatter of the next); then compound 1.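

The exchange on the amine nitrogen is the first change shown away from the chain on the other amide, and with the octadecyl chain held constant it gives an at least 6.1-fold lower number from compound 3 to compound 4 (0.78 log units; beyond the scatter). The earlier compounds shown here showed the number moving only with chain length, whereas this step shows that in this assay the group on the amine nitrogen also moves it, so the octadecyl chain does not by itself hold a compound at the limit. The size of the step stays open because the value of compound 3 is a limit: the limit of > 200000 nM in this assay, at which 1 of the 4 values shown sits.

The exchange alters several things at once, replacing a carbonyl with a sulfonyl and the fused pair of a five-membered and a six-membered aromatic ring with a single six-membered aromatic ring, so the compounds shown do not say which of these carries the step; a (4-methylphenyl)carbonyl group on the same nitrogen would separate them. They also leave open whether (4-methylphenyl)sulfonyl acts alike on a shorter chain such as the octyl or dodecyl chain, where the numbers start from a different place.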